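Amino for hydroxy on a fused diazine core

A few compounds are considered here, and "the series" means these few. Any claim that something is new, unique, unknown or untested is made for them only; others in the source may bear on it.

Measured so far:
compound 1, `Nc1nc(O)c2cc(Sc3ccc4ccccc4c3)ccc2n1`, 7.35
compound 2, `Oc1nc(S)nc2ccc(Sc3ccc4ccccc4c3)cc12`, 5
compound 3, `Cc1c(NC(=O)C(Sc2ccc3ccccc3c2)C(C)C)ccc2nc(N)nc(N)c12`, 7.68

In an assay for inhibition of Dihydrofolate reductase (Homo sapiens) (on this read-out higher numbers stand for higher potency (the scale is a negative logarithm) and lower numbers for lower potency), compound 2 stands lowest of the three measured compounds; compound 1 sits nearest, and compound 3 furthest, both well beyond the scatter above it. For the measured compounds named here, the only single-point step measured so far, a number 2.35 log units lower from compound 1 to compound 2 (beyond the scatter), shows how much a single group on this core can move the read-out.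

Compound 4, `Nc1nc(S)nc2ccc(Sc3ccc4ccccc4c3)cc12`, is the next compound to be measured. It differs from compound 2 by amino in place of hydroxy on an aromatic carbon.

Going by the values given here, no measured pair isolates exactly this change. What the data do give is that the measured step of a number 2.35 log units lower from compound 1 to compound 2 (beyond the scatter) was large, and that compound 3, which carries two amino groups on its core, gives 7.68, while compound 1, which pairs an amino with a hydroxy, gives 7.35. On this basis a step upward from compound 2 is expected in this assay, but its size is uncertain.

The estimate for compound 4 in this assay is 6, with a range from 5 to 7. The expected step of a number 1.00 log units higher from compound 2 to compound 4 (beyond the scatter) is therefore beyond the scatter and in the direction of higher potency.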

Compound 4, logarithm of the reciprocal of the active concentration, log(1/C): 5.52
Beside the measured number, compound 4's estimate is 0.48 log units above it; the range from low to high includes it.
By their numbers in this assay, from the lowest: compound 2; then compound 4; then compound 1; then compound 3.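

In this assay, for the compounds shown here, placing amino instead of hydroxy on the aromatic carbon next to the ring nitrogen gives a number 0.52 log units higher from compound 2 to compound 4 (beyond the scatter), the first measured single change at this position. The step lies beyond the scatter even though the two groups match in the computed counts of heavy atoms, hydrogen-bond donors and hydrogen-bond acceptors, so those counts alone do not predict the read-out at this position. It is a modest step, while the earlier large one, a number 2.35 log units lower from compound 1 to compound 2 (beyond the scatter), came from a change at a different place on the shared core, so the two steps describe separate positions. Nothing available here explains why this change moves the read-out.

Going by these compounds, it remains open whether a methylamino or methoxy group at this position would raise or lower the number further, which would show how far this position tolerates larger groups. It is also unknown whether the amino-for-hydroxy step keeps its size and direction when the sulfanyl group elsewhere on the core is replaced by an amine.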